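From Fluorine to Bromine on the Pendant Phenyl

This account rests on a few compounds, and the source may have more. Where it says the series, first, only, none or still open, it means among the compounds named here.

Three esters built on one shared core have been tested in a functional assay on DU-145 cells (Homo sapiens) for antiproliferative activity, read by MTT assay, with a stated time of 48 h; on this read-out lower numbers stand for stronger inhibition and higher numbers for weaker inhibition. Compound 1 `C/C(=C\CC/C(C)=C/CC[C@@H]1[C@@]2(C)CCC(=O)C(C)(C)[C@H]2CC[C@@]1(C)O)CC/C=C(\C)C(=O)OCc1cn(-c2cccc(Cl)c2)nn1` gives 103000 nM. For compound 2 `C/C(=C\CC/C(C)=C/CC[C@@H]1[C@@]2(C)CCC(=O)C(C)(C)[C@H]2CC[C@@]1(C)O)CC/C=C(\C)C(=O)OCc1cn(-c2ccc(F)c(Cl)c2)nn1` the assay reports only a limit, > 150000 nM. Compound 3 `C/C(=C\CC/C(C)=C/CC[C@@H]1[C@@]2(C)CCC(=O)C(C)(C)[C@H]2CC[C@@]1(C)O)CC/C=C(\C)C(=O)OCc1cn(-c2ccccc2F)nn1` likewise stands at a limit, > 150000 nM. The step of an at least 1.4-fold higher number from compound 1 to compound 3 (0.16 log units; that floor lies within the scatter) points to weaker inhibition, though its floor lies within the scatter, and an at least 1.4-fold higher number from compound 1 to compound 2 (0.16 log units; that floor lies within the scatter) reads the same way, while a step that the two limits leave unreadable from compound 2 to compound 3 cannot be read because the limit of > 150000 nM in this assay, at which 2 of the 3 values shown sit, holds both values. Compound 4 `C/C(=C\CC/C(C)=C/CC[C@@H]1[C@@]2(C)CCC(=O)C(C)(C)[C@H]2CC[C@@]1(C)O)CC/C=C(\C)C(=O)OCc1cn(-c2cccc(Br)c2)nn1` carries 3-bromophenyl in place of 2-fluorophenyl on an aromatic nitrogen, bringing back a halogen-bearing phenyl much like that of compound 1. Since compound 1 with 3-chlorophenyl gives 103000 nM, compound 4 is expected to return toward that level, a step of an at least 1.3-fold lower number from compound 3 to compound 4 (0.13 log units; that floor lies within the scatter), with an estimate of 110000 nM spanning 55000 nM to 220000 nM.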

Compound 4, half-maximal inhibitory concentration: > 150000 nM
Compound 4 ended at the assay's limit; the forecaster's own chance of this, stated with the estimate: 35%; at least 1.3-fold (0.13 log units) between middle value and limit.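

Bromo in place of chloro on an aromatic carbon gives an at least 1.4-fold higher number from compound 1 to compound 4 (0.16 log units; that floor lies within the scatter) and brings back no measured number, so compound 1 remains the only one of the four compounds with a number rather than a limit. Even this close swap of one halogen for another therefore gives no sign of stronger inhibition. The steps to compound 4 from compound 2 and compound 3 cannot be read because all three values are the same limit: the limit of > 150000 nM in this assay, at which 3 of the 4 values shown sit. Still open, going by these compounds, is whether any group on this phenyl can give stronger inhibition, such as an amine or a carboxylic acid.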